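Hydrazone thiazoles: dropping the trifluoromethyl group

This account rests on a few compounds, and the source may have more. Where it says the series, first, only, none or still open, it means among the compounds named here.

Measured so far:
compound 1 `COc1cc(/C=N/Nc2nc(-c3ccc(Br)cc3)cs2)cc(Br)c1OC`: 27900 nM
compound 2 `COc1cc(/C=N/Nc2nc(-c3ccc(C(F)(F)F)cc3)cs2)c(Br)c(Br)c1OC`: > 100000 nM
compound 3 `Fc1ccc(/C=N/Nc2nc(-c3ccc(F)c(F)c3)cs2)cc1F`: 43900 nM

In a functional assay on U-87MG ATCC cells for inhibition, with U-87 MG (Homo sapiens) as the target, read by MTT assay, with a stated time of 48 h (a higher number here means a weaker inhibitor, a lower number a stronger inhibitor), compound 1 gives 27900 nM and compound 3 gives 43900 nM. For compound 2 only a limit was recorded, > 100000 nM, so compound 2 stands at the limit of > 100000 nM in this assay, at which 1 of the 3 values shown sits, and has no number of its own. Compound 4 `COc1cc(/C=N/Nc2nc(-c3ccccc3)cs2)c(Br)c(Br)c1OC` carries the change (hydrogen in place of trifluoromethyl on an aromatic carbon). Among the compounds with values here, no step between two measured compounds covers this change, so the expected size rests on little. Since compound 1, also a dimethoxy hydrazone on the shared core, gives 27900 nM, compound 4 is expected to return a number rather than a limit, with the step of an at least 2.2-fold lower number from compound 2 to compound 4 (0.34 log units; beyond the scatter) read as a gain of uncertain size. The estimate for compound 4 is 45000 nM, within 12000 nM to 150000 nM.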

Compound 4, half-maximal inhibitory concentration: 20100 nM
Beside the measured number, compound 4's estimate is 2.2-fold (0.35 log units) above it, within the range that was stated.
By their numbers in this assay, from the lowest: compounds 4, 1 and 3 (each within the scatter of the next, the first and the last beyond it). At a limit, above all of these: compound 2.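

Going from 4-(trifluoromethyl)phenyl to phenyl on the shared core gives the first single-place comparison in the series, and in this assay it reads as an at least 4.9-fold lower number from compound 2 to compound 4 (0.69 log units; beyond the scatter). Compound 4 returns a number, 20100 nM, so trifluoromethyl at this position is not needed for a measurable value. The entry for compound 2 is a limit: the limit of > 100000 nM in this assay, at which 1 of the 4 values shown sits.

Going by these compounds, the full size of the step stays open, as does whether it carries over to the other substitution patterns on the shared core. On these data alone, how an amine or a carboxylic acid in place of this hydrogen would read also stays open.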